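Estimating Compound 3 From Two Measured Analogues

The source may report more compounds than this note shows. Statements on the series, on what has been measured and on what is new or still open speak of the compounds shown alone.

Measured compounds:
compound 1 `CCOC(=O)C1=C(N/N=C(/C#N)C(=O)OCC)Nc2[nH]nc(C)c2C1c1ccc(N(C)C)cc1`: 35600 nM
compound 2 `CCOC(=O)C1=C(N/N=C(/Br)c2ccccc2)Nc2[nH]nc(C)c2C1c1ccc(N(C)C)cc1`: 78400 nM

Of the compounds shown here, two have been measured in a functional assay on MCF7 cells (Homo sapiens) for inhibition, read by MTT assay, with a stated time of 48 h; on this read-out higher numbers stand for weaker inhibition and lower numbers for stronger inhibition. Compound 1 `CCOC(=O)C1=C(N/N=C(/C#N)C(=O)OCC)Nc2[nH]nc(C)c2C1c1ccc(N(C)C)cc1` gives 35600 nM, and compound 2 `CCOC(=O)C1=C(N/N=C(/Br)c2ccccc2)Nc2[nH]nc(C)c2C1c1ccc(N(C)C)cc1` gives 78400 nM. Among the compounds with values here, compound 1 thus has the lowest number of the two, and the only measured step, a 2.2-fold higher number from compound 1 to compound 2 (0.34 log units; beyond the scatter), is modest. Compound 3 `CCOC(=O)C(=NNC1=C(C(=O)OCC)C(c2ccc(N(C)C)cc2)c2c(C)n[nH]c2N1)C(=O)OCC` has not yet been measured. It differs from compound 1 as follows: a group of 12 heavy atoms (7 carbon, 1 nitrogen, 4 oxygen; no ring) in place of a group of 9 heavy atoms (5 carbon, 2 nitrogen, 2 oxygen; no ring), on an amine nitrogen. Within the data shown here, the single measured step changes the same amine nitrogen and is therefore the only one that bears on this change, yet it exchanges a different pair of groups, so it offers only a rough guide to size. The step of a 1.1-fold higher number from compound 1 to compound 3 (0.05 log units; within the scatter) is expected to lie within the scatter, or at most to be modest, since a 2.2-fold higher number from compound 1 to compound 2 (0.34 log units; beyond the scatter) was itself modest. Compound 3 is estimated at 40000 nM, with a range from 15000 nM to 110000 nM.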

Compound 3, half-maximal inhibitory concentration: 89800 nM
Compound 3: middle estimate off by 2.2-fold (0.35 log units), on the low side, within the range that was stated.
By their numbers in this assay, from the lowest: compound 1; then compounds 2 and 3 (each within the scatter of the next).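

In this assay, putting the larger open-chain group of compound 3 on the amine nitrogen in place of the group of compound 1 gives a 2.5-fold higher number from compound 1 to compound 3 (0.40 log units; beyond the scatter) and thus a second substituent at this position that stands apart from compound 1 by more than the scatter. The ring-bearing group of compound 2 and the ring-free group of compound 3 cannot be told apart, with a 1.1-fold higher number from compound 2 to compound 3 (0.06 log units; within the scatter) even though they share no ring and only compound 2 carries bromine. Nothing measured here explains why these groups behave as they do.

The compounds shown leave open whether any group at this nitrogen would bring the number below that of compound 1. A carboxylic acid or a primary amide in place of the nitrile of compound 1 would show whether the nitrile itself matters.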